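Closing the amidine of compound 3 into a ring

The compounds below may be only part of what the source reports. "The series", "measured", "known", "first", "only" and "open" are said of these compounds alone.

Compound 3 `COc1ccc(Sc2ccc(C(=N)N)cc2)cc1` stands highest of the three numbers in an assay (Rattus norvegicus) for binding affinity to prostacyclin receptor (Homo sapiens), read by radioligand binding; a lower number here means a stronger inhibitor, a higher number a weaker inhibitor: compound 3 gives 1260 nM, while compound 1 `CC/N=C(\N)Nc1ccc(Sc2ccc(OC)cc2)cc1` gives 251 nM and compound 2 `COc1ccc(Sc2ccc(NC3=NC(C)CN3)cc2)cc1` gives 63.1 nM. Compound 4 `COc1ccc(Sc2ccc(C3=NCCN3)cc2)cc1` differs from compound 3 in one place: a group of 5 heavy atoms (3 carbon, 2 nitrogen; one five-membered non-aromatic ring with 2 hetero atoms) in place of a group of 3 heavy atoms (1 carbon, 2 nitrogen; no ring), on an aromatic carbon. The measured step that bears most directly on this change is the corresponding ring closure on a nitrogen on an aromatic ring, a 4.0-fold lower number from compound 1 to compound 2 (0.60 log units; beyond the scatter). The two steps that exchange the ring-bearing or open guanidine for the open amidine, a 20-fold higher number from compound 2 to compound 3 (1.30 log units; beyond the scatter) and a 5.0-fold higher number from compound 1 to compound 3 (0.70 log units; beyond the scatter), show that the larger part of the difference between them goes with the ring being present or absent. Treating the closure in compound 4 as the same kind of change, a modest step towards a lower number is expected, about a 4.2-fold lower number from compound 3 to compound 4 (0.62 log units; beyond the scatter). Compound 4 is therefore estimated at 300 nM, with a range of 100 nM to 900 nM.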

Compound 4, inhibition constant: 316 nM
For compound 4 the middle estimate is 1.1-fold (0.02 log units) below the measured one, and the stated range covers the measured number.
By their numbers in this assay, from the lowest: compound 2; then compounds 1 and 4 (each within the scatter of the next); then compound 3.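

On an aromatic carbon, the five-membered non-aromatic ring with 2 hetero atoms in place of the open amidine gives in this assay a step (a 4.0-fold lower number from compound 3 to compound 4 (0.60 log units; beyond the scatter)) of the same printed size as the ring closure on nitrogen (a 4.0-fold lower number from compound 1 to compound 2 (0.60 log units; beyond the scatter)), so the ring step is now seen at both attachments. The ring alone does not set the number, however: the ring on carbon stays short of the methyl-bearing ring on nitrogen (a 5.0-fold higher number from compound 2 to compound 4 (0.70 log units; beyond the scatter)) and sits level with the open ethyl guanidine (a 1.3-fold higher number from compound 1 to compound 4 (0.10 log units; within the scatter)). No measurement on hand accounts for these steps.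

The step between compound 2 and compound 4 changes the nitrogen link and the methyl together, so neither can be read alone. Going by these compounds, how a six-membered ring or a plain amine would stand at this position remains open.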